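Swapping butylamino for 2,4-dioxopiperidin-1-yl on the carbonyl carbon

The source may report more compounds than this note shows. Statements on the series, on what has been measured and on what is new or still open speak of the compounds shown alone.

Compound 3 (`CCCCNC(=O)c1c(N)sc(-c2ccc(Cl)cc2)c1-c1ccc(Cl)cc1`) gives 8170 nM in a functional assay on A549 cells (Homo sapiens) for inhibition, read by sulforhodamine B assay, with a stated time of 72 h (a lower number here means a stronger inhibitor, a higher number a weaker inhibitor), and has two relatives with a ring on the carbonyl carbon to compare with. Compound 1 (`Nc1sc(-c2ccc(Cl)cc2)c(-c2ccc(Cl)cc2)c1C(=O)N1CCCCC1`) gives 4620 nM and lies within the scatter of compound 3, while compound 2 (`Nc1sc(-c2ccc(Cl)cc2)c(-c2ccc(Cl)cc2)c1C(=O)N1CCOCC1`) gives 1870 nM and is the only one clearly apart from it, at a lower number. The next change leads to compound 4 (`Nc1sc(-c2ccc(Cl)cc2)c(-c2ccc(Cl)cc2)c1C(=O)N1CCC(=O)CC1=O`), in which 2,4-dioxopiperidin-1-yl stands in place of butylamino on a carbonyl carbon (2,4-dioxopiperidin-1-yl in place of butylamino on a carbonyl carbon). Among the compounds with values here, two measured steps bear on this, both running the opposite way, from a ring to butylamino: a 1.8-fold higher number from compound 1 to compound 3 (0.25 log units; within the scatter) stays inside the scatter and a 4.4-fold higher number from compound 2 to compound 3 (0.64 log units; beyond the scatter) goes beyond it. The step of a 2.5-fold lower number from compound 1 to compound 2 (0.39 log units; beyond the scatter) shows that the choice of ring alone also moves the number. Within the data shown here, no measured compound carries the 2,4-dioxopiperidin-1-yl group, so the size remains uncertain. Read in reverse, these steps suggest a modest fall, with the number landing among those of the two ring compounds. Expected on this reading is a 2.7-fold lower number from compound 3 to compound 4 (0.44 log units; beyond the scatter) in this assay as the likely size. The estimate for compound 4 is 3000 nM (expected range 1000 nM to 9000 nM).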

Compound 4, half-maximal inhibitory concentration: 4090 nM
The estimate for compound 4 lay 1.4-fold (0.13 log units) below the measured number, and the stated range covers the measured number.
By their numbers in this assay, from the lowest: compound 2; then compounds 4, 1 and 3 (each within the scatter of the next).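

At this position on the carbonyl carbon, in this assay the exchange of the open butylamino chain for a ring carrying two carbonyl groups gives a 2.0-fold lower number from compound 3 to compound 4 (0.30 log units; within the scatter) and so does not separate the two compounds. Among the ring compounds, the change from piperidin-1-yl to 2,4-dioxopiperidin-1-yl gives a 1.1-fold lower number from compound 1 to compound 4 (0.05 log units; within the scatter) and again no separation, whereas the change from morpholin-4-yl gives a 2.2-fold higher number from compound 2 to compound 4 (0.34 log units; beyond the scatter) and leaves compound 2 as the only one of the four clearly apart from all the others. Oxygen on the ring group is therefore not enough in itself to match compound 2, since compound 4 carries oxygen there and still cannot be told apart from compound 1, whose ring has none, and nothing available explains these differences.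

From the compounds shown here alone, how a piperazin-1-yl ring, or a piperidin-1-yl ring bearing a single carbonyl group, would read on this carbonyl carbon remains open, and so does the effect of a shorter chain such as ethylamino. Also open, going by these compounds, is whether the picture in this assay would hold for any other cell line.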